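Aryl-to-aryl swap at the chain end of compound 1

This account rests on a few compounds, and the source may have more. Where it says the series, first, only, none or still open, it means among the compounds named here.

Measured so far:
- compound 1, `COc1cccc(Cc2cnc(CCc3ccc(-c4ccccc4C(=O)O)cc3)[nH]2)c1`, 4120 nM
- compound 2, `COc1ccc(Cc2cnc(CCc3ccc(-c4ccccc4C(=O)O)cc3)[nH]2)cc1`, 5360 nM
- compound 3, `O=C(O)c1ccccc1-c1ccc(CCc2ncc(CCC3CCCCC3)[nH]2)cc1`, 642 nM

Three compounds share the same core and differ only in the group on a saturated chain carbon bound to an aromatic carbon. In an in vitro functional assay on cells for agonist activity at Bombesin receptor subtype-3 (Homo sapiens), read by luminescence and calcium flux (on this read-out higher numbers stand for an effect only at larger amounts of compound and lower numbers for an effect already at smaller amounts), compound 1 gives 4120 nM, the second highest of the three numbers. Its nearest neighbour is compound 2: a 1.3-fold higher number from compound 1 to compound 2 (0.11 log units; within the scatter). The one clear move in the set is to compound 3: a 6.4-fold lower number from compound 1 to compound 3 (0.81 log units; beyond the scatter), and likewise an 8.3-fold lower number from compound 2 to compound 3 (0.92 log units; beyond the scatter).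

Compound 4, `Cc1ccc(Cc2cnc(CCc3ccc(-c4ccccc4C(=O)O)cc3)[nH]2)cc1`, is not yet measured. It differs from compound 1 as 4-methylphenyl in place of 3-methoxyphenyl on a saturated chain carbon bound to an aromatic carbon. Among the compounds with values here, no measured step describes exactly this change. Within the data shown here, the only aryl-to-aryl step available, from compound 1 to compound 2, moved the oxygen-bearing group around the ring and stayed within the scatter. The step to compound 3 replaced the aromatic ring altogether and is not a close guide for compound 4, where the ring is kept. On this basis a change within the scatter is expected, as a 1.2-fold lower number from compound 1 to compound 4 (0.07 log units; within the scatter). Compound 4 is therefore estimated at 3500 nM in this assay, with a range from 1200 nM to 10000 nM.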

Compound 4, half-maximal effective concentration: 2660 nM
For compound 4 the middle estimate is 1.3-fold (0.12 log units) above the measured one; the range from low to high includes it.
By their numbers in this assay, from the lowest: compound 3; then compounds 4, 1 and 2 (each within the scatter of the next).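

In this assay, within the data shown here, this is the first step at this position that changes the ring substituent itself rather than its place: methyl for methoxy gives a 2.0-fold lower number from compound 2 to compound 4 (0.30 log units; within the scatter) and, with the place changed as well, 4-methylphenyl for 3-methoxyphenyl gives a 1.5-fold lower number from compound 1 to compound 4 (0.19 log units; within the scatter) (the hydrogen-bond acceptor count of the group falls from 1 to 0). Compounds 1, 2 and 4 therefore all lie within the scatter of each other, so in these three substituted aryl compounds neither the oxygen of the methoxy group nor its place on the ring shows a measurable effect, while cyclohexylmethyl remains apart, with a 4.1-fold higher number from compound 3 to compound 4 (0.62 log units; beyond the scatter) confirming that separation from a third aryl compound. No supporting data are available to explain either the flat aryl steps or the separation of compound 3.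

Still open, going by these compounds, is whether a ring substituent of another kind, such as an amine, a carboxylic acid or a fluorine atom, would leave the scatter. Also open, on these data alone, is whether the separation of compound 3 follows from the saturated ring or from the longer chain, which a 2-phenylethyl group or a directly attached cyclohexyl group on the shared core would help to divide.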